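The compounds below may be only part of what the source reports. "The series", "measured", "known", "first", "only" and "open" are said of these compounds alone.

Of the compounds shown here, three have been measured in an assay on HEK293 cells for positive allosteric modulation of metabotropic glutamate receptor 5 (Homo sapiens), read by FLIPR; a higher number here means that more compound is needed for the effect, a lower number that less compound is needed. Compound 1 `O=C(C1CCC(F)(F)CC1)N1CC(c2nc(-c3cccc(Cl)c3)no2)C1` gives 180 nM, the second highest of the three numbers. Compound 2 `O=C([C@H]1CC2CCC1C2)N1CC(c2nc(-c3ccccc3)no2)C1` gives 120 nM, and this lies within the usual scatter of the value for compound 1, so the two cannot be told apart. Compound 3 `O=C(C1CCCCC1)N1CC(c2nc(-c3cccc(F)c3)no2)C1` gives 1000 nM, a clearly higher number than that of compound 1, beyond the scatter. Compound 4 `CC1CN(C(=O)N2CC(c3nc(-c4cccc(Cl)c4)no3)C2)CC(C)O1` has not yet been measured. It differs from compound 1 in one place: 2,6-dimethylmorpholin-4-yl in place of 4,4-difluorocyclohexyl on a carbonyl carbon. Among the compounds with values here, with no measured pair showing this kind of exchange, the expectation rests on compound 1 alone. A modest step toward a higher number, close to the scatter, seems most likely, giving an expected 1.7-fold higher number from compound 1 to compound 4 (0.22 log units; within the scatter). Compound 4 is therefore estimated at 300 nM, between 100 nM and 900 nM.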

Compound 4, half-maximal effective concentration: > 10000 nM
Compound 4 ended at the assay's limit; the forecaster's own chance of this, stated with the estimate: 5%; middle value at least 33-fold (1.52 log units) away from the limit.
By their numbers in this assay, from the lowest: compounds 2 and 1 (each within the scatter of the next); then compound 3. At a limit, above all of these: compound 4.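

Swapping 4,4-difluorocyclohexyl for 2,6-dimethylmorpholin-4-yl on this carbonyl carbon gives an at least 55-fold higher number from compound 1 to compound 4 (1.74 log units; beyond the scatter), so this place does not accept every six-membered ring, even one with the same count of heavy atoms. The three earlier compounds, all with carbon-only rings here, gave measurable numbers. Compound 4 stands at a limit of the assay, not at a number: the limit of > 10000 nM in this assay, at which 1 of the 4 values shown sits.

The compounds shown cannot tell whether the ring oxygen, the ring nitrogen on the carbonyl or the two methyl groups matter. Piperidine or unsubstituted morpholine at this place would separate these.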